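A Hexyl Chain Gives Way to Benzyl

The source may report more compounds than this note shows. Statements on the series, on what has been measured and on what is new or still open speak of the compounds shown alone.

In a functional assay on A549 cells (Homo sapiens) for antiproliferative activity, read by MTT assay, with a stated time of 48 h (on this read-out higher numbers stand for weaker inhibition and lower numbers for stronger inhibition), compound 2 `CCCCCC1(O)C(=O)Nc2ccc(Nc3ccc(OC)cc3)cc21` gives 8000 nM and compound 3 `CCCCCCC1(O)C(=O)Nc2ccc(Nc3ccc(OC)cc3)cc21` gives 18600 nM, the higher of these two numbers. Compound 1 `Cc1ccc(Nc2ccc3c(c2)C(CC2CCCCC2)C(=O)N3)cc1` reaches only a limit, > 30000 nM. Compound 4 `COc1ccc(Nc2ccc3c(c2)C(O)(Cc2ccccc2)C(=O)N3)cc1` has phenyl in place of pentyl on a saturated chain carbon bound to a saturated ring carbon, so hexyl becomes benzyl (phenyl in place of pentyl on a saturated chain carbon bound to a saturated ring carbon). Among the compounds with values here, the one measured step on this chain is modest: a 2.3-fold higher number from compound 2 to compound 3 (0.37 log units; beyond the scatter). It involves no ring, so it is only a rough guide, and a small change is expected in this assay, leaning lower. The expected step is a 1.6-fold lower number from compound 3 to compound 4 (0.19 log units; within the scatter), which is no clear shift. Compound 4 is estimated at 12000 nM, with an expected range of 4000 nM to 30000 nM.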

Compound 4, half-maximal inhibitory concentration: > 30000 nM
Compound 4: only a limit was reported; the forecaster's own chance of this, stated with the estimate: 15%; at least 2.5-fold (0.39 log units) between middle value and limit.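

In this assay, on these data alone, compound 4 gives only a limit (> 30000 nM), so its true value stays unknown: the limit of > 30000 nM in this assay, at which 2 of the 4 values shown sit. Set against hexyl, benzyl yields only a floor that does not separate the two compounds (an at least 1.6-fold higher number from compound 3 to compound 4 (0.20 log units; that floor lies within the scatter)). Set against the shorter pentyl chain, the loss is clear (an at least 3.7-fold higher number from compound 2 to compound 4 (0.57 log units; beyond the scatter)), so a ring on this chain brings no gain over either plain chain. Still open, as far as these compounds go, is how far the benzyl compound really falls, and whether an amine or a carboxylic acid at the end of this chain would fare better.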